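From propanoyl to pentylcarbonyl: what compound 3 may show

The source may hold more compounds than are shown below. What is called first, only, known or untested is meant among the compounds shown, and "the series" means these compounds.

Of the compounds shown here, two built on one shared core have been measured. Compound 1 `C=C1CC[C@@H]2[C@](C)(CO)[C@H](O)CC[C@@]2(C)[C@@H]1CC(OC(C)=O)C1=CCOC1=O` gives 95.1% in a functional assay on J774.A1 cells (Mus musculus) for inhibition, read by ELISA, with a stated time of 24 h, tested at 20 uM; a lower number here means less inhibition, a higher number more inhibition at the concentration tested (going by the name of the read-out). Compound 2 `C=C1CC[C@@H]2[C@](C)(CO)[C@H](O)CC[C@@]2(C)[C@@H]1CC(OC(=O)CC)C1=CCOC1=O` gives 82.6% in this assay. Among the measured compounds shown here, of the two numbers, compound 2 stands lowest; its only neighbour is compound 1, and the step of a number 12.5 percentage points lower from compound 1 to compound 2 (beyond the scatter) went with methyl in place of hydrogen on a saturated chain carbon bound to a carbonyl carbon.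

Compound 3 `C=C1CC[C@@H]2[C@](C)(CO)[C@H](O)CC[C@@]2(C)[C@@H]1CC(OC(=O)CCCCC)C1=CCOC1=O` has not yet been measured. Its difference from compound 2 is propyl in place of hydrogen on a saturated chain carbon, two bonds along the chain from a carbonyl carbon. For the measured compounds named here, the single measured step that bears on this change is a number 12.5 percentage points lower from compound 1 to compound 2 (beyond the scatter), a modest drop for a small addition on the same chain. Going by the values given here, nothing among the measured compounds shows whether a further addition on that chain carries the drop onward, so the expectation rests on that one step alone. Compound 3 is therefore expected to show the step of a number 12.6 percentage points lower from compound 2 to compound 3 (beyond the scatter), downward and of a size near the earlier one, with a wide range. The estimate for compound 3 is 70%, between 45% and 90%.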

Compound 3, a percentage reported as inhibition, at one concentration (the size of the read-out at that concentration, not a potency): 82.9%
Compound 3: middle estimate off by 12.9 percentage points, on the low side; the measured number falls inside the stated range.
By their numbers in this assay, from the lowest: compounds 2 and 3 (each within the scatter of the next); then compound 1.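

In this assay, propyl in place of hydrogen on a saturated chain carbon, two bonds along the chain from a carbonyl carbon, goes with a number 0.3 percentage points higher from compound 2 to compound 3 (within the scatter), so the propanoyl and pentylcarbonyl groups cannot be told apart at this place, and the added propyl does not carry on the drop seen with the first methyl. Taken as a whole, the longer chain goes with a number 12.2 percentage points lower from compound 1 to compound 3 (beyond the scatter), a step of much the same size as a number 12.5 percentage points lower from compound 1 to compound 2 (beyond the scatter), so among these three compounds the only separation beyond the scatter is that of compound 1 from compound 2 and from compound 3. Nothing at hand gives a reason for this flat stretch of the chain.

The compounds shown leave open whether a longer chain such as decanoyl, a branched chain such as pivaloyl, or a chain ending in an amine or a carboxylic acid would hold the number where compound 2 and compound 3 stand. Since each number is the size of the read-out at one concentration, they also leave open whether compound 2 and compound 3 would stay level at lower concentrations.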